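The source may report more compounds than this note shows. Statements on the series, on what has been measured and on what is new or still open speak of the compounds shown alone.

Working notes on the series.

Within the data shown here, compound 2 `Cc1ccccc1C(=O)c1ccc2c(c1)C(n1ccccc1=O)=CC(C)(C)O2` gives the higher of the two numbers so far in a functional assay (trachea) with Rattus norvegicus as the target (on this read-out higher numbers stand for higher potency (the scale is a negative logarithm) and lower numbers for lower potency), at 6.25. Compound 1 `CC1(C)C=C(n2ccccc2=O)c2cc(C(=O)c3ccccc3)ccc2O1` gives 6.21 in this assay, and the step of a number 0.04 log units higher from compound 1 to compound 2 (within the scatter) lies within the scatter, so the two compounds cannot be ordered. Compound 3 `CC1(C)C=C(n2ccccc2=O)c2cc(C#N)ccc2O1` has not yet been measured in this assay. It differs from compound 2 by cyano in place of (2-methylphenyl)carbonyl on an aromatic carbon. Among the measured compounds shown here, the one measured step, methyl in place of hydrogen on an aromatic carbon of the (2-methylphenyl)carbonyl group, concerns a part that is removed here and does not speak to the exchange of the whole group for cyano. For the measured compounds named here, no measured step therefore bears on this change, and the expectation rests only on the two numbers in hand, both close together. The estimate for compound 3 in this assay is 6.3, within 5.5 to 7.1, an expected step of a number 0.05 log units higher from compound 2 to compound 3 (within the scatter) that stays close to compound 2 but with wide uncertainty.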

Compound 3, logarithm of the reciprocal of the active concentration, log(1/C): 7.1
Compound 3: middle estimate off by 0.80 log units, on the low side; the range from low to high includes it.
By their numbers in this assay, from the lowest: compounds 1 and 2 (each within the scatter of the next); then compound 3.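

In this assay, this aromatic carbon of the shared core responds to the exchange of the whole group: cyano in place of (2-methylphenyl)carbonyl gives a step beyond the scatter (a number 0.85 log units higher from compound 2 to compound 3 (beyond the scatter)), whereas the added methyl on the benzoyl ring had not moved the number beyond it. Cyano in place of benzoyl gives a similar step (a number 0.89 log units higher from compound 1 to compound 3 (beyond the scatter)), so the rise holds from both aryl carbonyl groups shown and does not depend on that methyl. No data at hand account for the rise.

The compounds shown leave open whether the rise belongs to cyano itself or to the loss of the aryl carbonyl group. They also leave open how a simple hydrogen, an amine or a carboxylic acid on this carbon would compare with cyano.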